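The source may report more compounds than this note shows. Statements on the series, on what has been measured and on what is new or still open speak of the compounds shown alone.

Of the compounds shown here, three have so far been measured in an assay on membranes from Sf9 cells for displacement of a labelled ligand from histamine H2 receptor (Homo sapiens), read by scintillation counting, with a stated time of 60 min; on this read-out lower numbers stand for stronger inhibition and higher numbers for weaker inhibition. Compound 1 `Cc1nc(N)sc1CCCN/C(N)=N/C(=O)NC(C)c1cccc(F)c1` gives 2.04 nM, the lowest of the three numbers. Compound 2 `CCCCCNC(=O)/N=C(\N)NCCCc1sc(N)nc1C` gives 4.47 nM, and the gap from compound 1 to compound 2 lies beyond the scatter, though it is the smaller of the two. Compound 3 `CCCNC(=O)/N=C(\N)NCCCc1sc(N)nc1C` gives 105 nM, the furthest from compound 1 and also beyond the scatter.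

Going by the values given here, only one step between compounds that differ in a single place can be drawn from these numbers: a 23-fold higher number from compound 2 to compound 3 (1.37 log units; beyond the scatter), which follows hydrogen in place of ethyl on a saturated chain carbon, three bonds along the chain from an amide-type nitrogen. It shows that this series responds strongly to a change on the chain of the amide-type nitrogen.

Compound 4 `Cc1nc(N)sc1CCCN/C(N)=N/C(=O)NC(C)c1ccccc1F` differs from compound 1 by 2-fluorophenyl in place of 3-fluorophenyl on a saturated chain carbon bound to an amide-type nitrogen and a saturated chain carbon. Among the compounds with values here, no measured pair shows what moving the fluorine on the aromatic ring does; the step from compound 2 to compound 3 alters a chain, not a ring, so it does not bear directly on this change. Compound 4 is therefore expected to stay close to compound 1, with a step of a 1.4-fold higher number from compound 1 to compound 4 (0.14 log units; within the scatter) that need not exceed the scatter. The estimate for compound 4 in this assay is 2.8 nM, with a range from 1 nM to 8 nM.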

Compound 4, inhibition constant: 28.8 nM
For compound 4 the middle estimate is 10-fold (1.01 log units) below the measured one; the measured number lies above the stated range.
By their numbers in this assay, from the lowest: compound 1; then compound 2; then compound 4; then compound 3.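

In this assay, exchanging 3-fluorophenyl for 2-fluorophenyl on the saturated chain carbon bound to an amide-type nitrogen and a saturated chain carbon gives a 14-fold higher number from compound 1 to compound 4 (1.15 log units; beyond the scatter), a large step beyond the scatter. The earlier compounds shown here showed a strong response only to a change in a chain, whereas this pair shows that the series also responds strongly at this aromatic group, even though the two groups have the same atoms and the same counts of rings, hydrogen-bond donors and acceptors, and differ only in where the fluorine stands on the ring. No measurement available here accounts for this step, so the data record its size and direction but give no explanation for it.

From the compounds shown here alone, with only these two fluorophenyl groups compared at this carbon, it remains open whether the 3-fluorophenyl of compound 1 is itself favourable or the 2-fluorophenyl of compound 4 is unfavourable. An unsubstituted phenyl or a cyclohexyl group at the same place would be needed to separate those two readings.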